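Aryl piperazine sulfonamides of the shared core: next substitution

This account rests on a few compounds, and the source may have more. Where it says the series, first, only, none or still open, it means among the compounds named here.

Measured so far:
- compound 1 `CCCn1c(=O)[nH]c2nc(-c3ccc(S(=O)(=O)N4CCN(c5cccc(Br)c5)CC4)cc3)[nH]c2c1=O`: 0.234 nM
- compound 2 `CCCn1c(=O)[nH]c2nc(-c3ccc(S(=O)(=O)N4CCN(C)CC4)cc3)[nH]c2c1=O`: 48.2 nM
- compound 3 `CCCn1c(=O)[nH]c2nc(-c3ccc(S(=O)(=O)N4CCN(c5ccc(I)cc5)CC4)cc3)[nH]c2c1=O`: 0.159 nM

All three were read in an assay on CHO cells for displacement of a labelled ligand from adenosine receptor A2b (Homo sapiens), read by scintillation counting, with a stated time of 75 min, in the presence of a further agent that is not named here; a higher number here means a weaker inhibitor, a lower number a stronger inhibitor. Among the three numbers compound 1 stands second highest; its nearest neighbour is compound 3, the step of a 1.5-fold lower number from compound 1 to compound 3 (0.17 log units; within the scatter) lying within the scatter, and its furthest is compound 2, the step of a 210-fold higher number from compound 1 to compound 2 (2.31 log units; beyond the scatter) being large. The step of a 300-fold lower number from compound 2 to compound 3 (2.48 log units; beyond the scatter) is likewise large.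

Compound 4 `CCCn1c(=O)[nH]c2nc(-c3ccc(S(=O)(=O)N4CCN(c5ccc(Cl)cc5F)CC4)cc3)[nH]c2c1=O` is not yet measured. The change from compound 1 is 4-chloro-2-fluorophenyl in place of 3-bromophenyl on an amine nitrogen in a ring. The step that bears on it is the swap of one aryl group for another, a 1.5-fold lower number from compound 1 to compound 3 (0.17 log units; within the scatter), which stayed within the scatter; the large steps involve a methyl and are not comparable. A step of a 1.1-fold higher number from compound 1 to compound 4 (0.03 log units; within the scatter) is therefore expected, no larger than the scatter. Compound 4 is estimated at 0.25 nM, in the range 0.1 nM to 0.7 nM.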

Compound 4, inhibition constant: 1.91 nM
For compound 4 the middle estimate is 7.6-fold (0.88 log units) below the measured one; the whole stated range lies below it.
By their numbers in this assay, from the lowest: compounds 3 and 1 (each within the scatter of the next); then compound 4; then compound 2.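

In this assay the aryl group on the amine nitrogen in a ring is not freely interchangeable: 4-chloro-2-fluorophenyl in place of 3-bromophenyl gives an 8.2-fold higher number from compound 1 to compound 4 (0.91 log units; beyond the scatter) and in place of 4-iodophenyl gives a 12-fold higher number from compound 3 to compound 4 (1.08 log units; beyond the scatter) while the earlier aryl swap stayed within the scatter. Compound 4 still keeps much of the gain over the methyl group, with a 25-fold lower number from compound 2 to compound 4 (1.40 log units; beyond the scatter) as the step. No evidence on the cause of these differences is available. The compounds shown do not separate the contributions of the fluorine and the chlorine in the entering group. Going by these compounds, whether plain phenyl or an aryl group bearing an amine or a carboxylic acid would read closer to compound 1 or to compound 4 stays open.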